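Swapping the ortho substituent of a diaryl urea helicase inhibitor

A few compounds are considered here, and "the series" means these few. Any claim that something is new, unique, unknown or untested is made for them only; others in the source may bear on it.

Measured so far:
compound 1 `CCCCc1cn(-c2ccc(NC(=O)Nc3ccccc3C(F)(F)F)cc2)nn1` — 400 nM
compound 2 `CCCCc1cn(-c2ccc(NC(=O)Nc3ccccc3OC3CCCC3)cc2)nn1` — 140 nM

For the measured compounds named here, in an assay on isolated protein for inhibition of ATP-dependent RNA helicase DDX3X (Homo sapiens) (a lower number here means a stronger inhibitor, a higher number a weaker inhibitor), compound 2 stands lowest of the two numbers; the only comparison is a 2.9-fold lower number from compound 1 to compound 2 (0.46 log units; beyond the scatter). Compound 3 `CCCCc1cn(-c2ccc(NC(=O)Nc3ccccc3F)cc2)nn1` carries a different change: fluoro in place of cyclopentyloxy on an aromatic carbon. Going by the values given here, no measured step covers fluoro, so the one step between compound 1 and compound 2 is only a loose guide; a larger group gave the lower number there, and fluoro is smaller still. A step back toward a higher number is therefore expected, of modest size, a 3.6-fold higher number from compound 2 to compound 3 (0.55 log units; beyond the scatter). Compound 3 is estimated at 500 nM, within a range from 150 nM to 1600 nM.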

Compound 3, half-maximal inhibitory concentration: 600 nM
Compound 3: middle estimate off by 1.2-fold (0.08 log units), on the low side; measured number inside the range.
By their numbers in this assay, from the lowest: compound 2; then compounds 1 and 3 (each within the scatter of the next).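

Fluoro in place of cyclopentyloxy gives a 4.3-fold higher number from compound 2 to compound 3 (0.63 log units; beyond the scatter), so compound 2 now stands apart from two compounds with much smaller groups at this position, not just one. Fluoro in place of trifluoromethyl gives a 1.5-fold higher number from compound 1 to compound 3 (0.18 log units; within the scatter), so these two groups cannot be told apart in this assay. Nothing available explains these differences.

As far as these compounds go, it remains open whether the gain comes from the oxygen or from the ring of cyclopentyloxy. A methoxy group and a directly attached cyclopentyl group at this position would separate the two.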